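A few compounds are considered here, and "the series" means these few. Any claim that something is new, unique, unknown or untested is made for them only; others in the source may bear on it.

Compound 1 `CCN(CC)S(=O)(=O)c1ccc(S(=O)(=O)N2CCC[C@@H](C(=O)N3CCC(F)(F)CC3)C2)cc1` and compound 2 `O=C([C@@H]1CCCN(S(=O)(=O)c2ccc(S(=O)(=O)C3CCC3)cc2)C1)N1CCC(F)(F)CC1` share one core and differ only at a sulfonyl sulfur. In a functional assay on MIA PaCa-2 cells (Homo sapiens) for inhibition, read by MTT assay, with a stated time of 3 days (a lower number here means a stronger inhibitor, a higher number a weaker inhibitor), compound 1 gives > 10000 nM, which is a limit of the assay rather than a number. In this assay compound 2 likewise gives > 3000 nM, again a limit and not a number. Going by the values given here, the one measured step, a step that the two limits leave unreadable from compound 1 to compound 2, cannot be read: the limit of > 10000 nM in this assay, at which 1 of the 2 values shown sits, and the limit of > 3000 nM in this assay, at which 1 of the 2 values shown sits, mark its two ends. Compound 3 `CCN(CC)S(=O)(=O)c1ccc(S(=O)(=O)N2CCC[C@@H](C(=O)N3CCS(=O)(=O)CC3)C2)cc1` differs from compound 1 in one place: 1,1-dioxothiomorpholin-4-yl in place of 4,4-difluoropiperidin-1-yl on a carbonyl carbon. Among the compounds with values here, no measured step touches this change; the only step known alters a different group and is itself unreadable. What can be said rests on the limit of compound 1 alone. With no inhibition seen at either measured compound, compound 3 is expected to remain out of reach of this assay as well, so the step that the limit leaves unreadable from compound 1 to compound 3 is expected to be nothing beyond the scatter, most likely with only a limit reported once more. Compound 3 is therefore estimated at 20000 nM, within 5000 nM to 100000 nM.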

Compound 3, half-maximal inhibitory concentration: > 10000 nM
Compound 3 was reported as a limit; the forecaster's own chance of this, stated with the estimate: 85%; the middle value does not contradict the limit.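

In this assay compound 3 gives > 10000 nM, which is a limit of the assay and not a number. Going by these compounds alone, compound 1 stands at a limit as well, so no step between compound 1 and compound 3 can be read. The compounds shown leave open whether either change, at the sulfonyl sulfur or on the carbonyl carbon, alters inhibition at all.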